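The compounds below may be only part of what the source reports. "The series", "measured", "known", "first", "only" and "open" are said of these compounds alone.

Among the measured compounds shown here, compound 1 `O=C(O)c1ccc2c(c1)CC(CNS(=O)(=O)c1ccc(Cl)cc1)C2` is one of three compounds so far measured in a functional assay on aorta for antagonist activity at thromboxane A2 receptor (Rattus norvegicus); a lower number here means a stronger inhibitor, a higher number a weaker inhibitor. In this assay compound 1 gives 26.3 nM. Compound 3 `O=C(O)Cc1ccc2c(c1)CC(CNS(=O)(=O)c1ccc3ccccc3c1)C2`, which carries a carboxymethyl acid and a naphthyl sulfonamide, gives 22.4 nM, a number so close to that of compound 1 that the two cannot be told apart. Compound 2 `O=C(O)c1ccc2c(c1)CC(CCNS(=O)(=O)c1ccc(Cl)cc1)C2`, in which the sulfonamide sits one methylene further from the core, gives 66.1 nM, which stands beyond the scatter above compound 1; compound 1 therefore sits second highest of the three, close to compound 3 and clearly below compound 2.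

The next compound, compound 4 `O=C(O)CCc1ccc2c(c1)CC(CNS(=O)(=O)c1ccc(Cl)cc1)C2`, keeps everything of compound 1 except the acid: 2-carboxyethyl in place of carboxy on an aromatic carbon. For the measured compounds named here, no directly comparable pair among the measured compounds shows the effect of lengthening the acid chain, so the expectation rests on the broad picture, in which compound 3 with its carboxymethyl acid gives 22.4 nM. For compound 4 the step is expected to be small, a 1.2-fold lower number from compound 1 to compound 4 (0.08 log units; within the scatter), with no clear direction beyond the scatter. Compound 4 is thus estimated at 22 nM, in a range from 7 nM to 70 nM.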

Compound 4, half-maximal inhibitory concentration: 14.8 nM
The estimate for compound 4 lay 1.5-fold (0.17 log units) above the measured number, and the stated range covers the measured number.
By their numbers in this assay, from the lowest: compounds 4, 3 and 1 (each within the scatter of the next); then compound 2.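

Among the compounds shown here, compound 4 gives the first direct reading at this position: in this assay, putting 2-carboxyethyl in place of carboxy on the aromatic carbon gives a 1.8-fold lower number from compound 1 to compound 4 (0.25 log units; within the scatter), with everything else in compound 1 kept. The acid can therefore stand at the end of a chain or directly on the aromatic ring without a change that can be told from the scatter, so this step shows no gain or loss in either direction. No measurement at hand bears on why the number stays in this range.

On these data alone, whether a longer chain, such as 3-carboxypropyl, would also leave the number within the scatter remains open. So does the outcome of putting an amine or a primary amide in place of the acid at this position.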